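Pentyl for tert-butyl on a shared core with no readable numbers

The source may hold more compounds than are shown below. What is called first, only, known or untested is meant among the compounds shown, and "the series" means these compounds.

Three compounds have been measured in an assay on isolated protein for inhibition of Polyunsaturated fatty acid lipoxygenase ALOX15 (Homo sapiens); on this read-out lower numbers stand for stronger inhibition and higher numbers for weaker inhibition:
Compound 1, `CC(C)c1cc(=O)c2ccc(O)cc2o1`, gives > 100000 nM, which is a limit of the assay and not a number.
Compound 2, `CC(C)Cc1oc2ccccc2c(=O)c1O`, gives > 100000 nM, which is a limit.
Compound 3, `CC(C)(C)c1oc2ccccc2c(=O)c1O`, gives > 100000 nM, which is a limit.

Compound 3 therefore stands nowhere on a scale of numbers: its result in this assay is a limit, as are the other two results shown, and every value sits at the limit of > 100000 nM in this assay, at which 3 of the 3 values shown sit. Going by the values given here, the one step that can be paired, a step that the two limits leave unreadable from compound 2 to compound 3, is unreadable because both ends are limits, so its size and direction remain unknown.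

Compound 4, `CCCCCc1oc2ccccc2c(=O)c1O`, carries the change (pentyl in place of tert-butyl on an aromatic carbon). Among the compounds with values here, no measured step bears on this change in a readable way: the only step available is unreadable, and no pair of numbers exists that the pentyl group could be compared against. The expectation can rest only on the fact that every result so far is a limit. For compound 4 the step that the limit leaves unreadable from compound 3 to compound 4 is expected to be small or none beyond the scatter, with the result most likely again a limit. Compound 4 is thus estimated at 150000 nM, between 40000 nM and 1000000 nM, in this assay.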

Compound 4, half-maximal inhibitory concentration: > 100000 nM
Compound 4 was reported as a limit (the forecaster's own chance of this, stated with the estimate: 80%); the middle value is on the limit's open side.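

In this assay compound 4 gives > 100000 nM as a limit of the assay and not a number. Going by these compounds alone, no step from compound 2 or compound 3 to compound 4 can be read: the limit of > 100000 nM in this assay, at which 4 of the 4 values shown sit. The compounds shown leave open whether isobutyl, tert-butyl or pentyl on the shared core makes any difference to inhibition, as none gives a number.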